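Replacing the Fluorophenyl Group of Compound 1 with Methoxyphenyl

A few compounds are considered here, and "the series" means these few. Any claim that something is new, unique, unknown or untested is made for them only; others in the source may bear on it.

Compound 1 `CC1(C)[C@H]2CC[C@]1(C)N(Cc1cn(-c3ccccc3F)nn1)C(=O)C2` was tested in a functional assay on LoVo cells (Homo sapiens) for inhibition, read by MTT assay, with a stated time of 24 h (a higher number here means a weaker inhibitor, a lower number a stronger inhibitor), where compound 1 gives 40 nM, the lowest number among the three measured compounds. Compound 2 `CC1(C)[C@H]2CC[C@]1(C)N(Cc1cn(-c3cccc(O)c3)nn1)C(=O)C2` gives 410 nM, and compound 3 `Cc1ccccc1-n1cc(CN2C(=O)C[C@@H]3CC[C@@]2(C)C3(C)C)nn1` gives 80 nM. In this assay there is a 10-fold higher number from compound 1 to compound 2 (1.01 log units; beyond the scatter), while there is only a 2.0-fold higher number from compound 1 to compound 3 (0.30 log units; within the scatter). Between the other two, there is a 5.1-fold lower number from compound 2 to compound 3 (0.71 log units; beyond the scatter).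

Compound 4 `COc1cccc(-n2cc(CN3C(=O)C[C@@H]4CC[C@@]3(C)C4(C)C)nn2)c1` has not yet been measured. It differs from compound 1 in one place: 3-methoxyphenyl in place of 2-fluorophenyl on an aromatic nitrogen. Going by the values given here, two measured steps bear on this change. Swapping 2-fluorophenyl for 3-hydroxyphenyl gave a 10-fold higher number from compound 1 to compound 2 (1.01 log units; beyond the scatter), a large weakening, whereas swapping fluoro for methyl gave a 2.0-fold higher number from compound 1 to compound 3 (0.30 log units; within the scatter), nothing beyond the scatter. The incoming 3-methoxyphenyl group resembles 3-hydroxyphenyl more closely than 2-methylphenyl, although it brings no hydrogen-bond donor. A weakening is therefore expected, probably smaller than that seen for compound 2, so compound 4 is expected to give 200 nM, in a range from 70 nM to 600 nM. This estimate corresponds to a 5.0-fold higher number from compound 1 to compound 4 (0.70 log units; beyond the scatter).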

Compound 4, half-maximal inhibitory concentration: 80 nM
Estimate against measurement, compound 4: 2.5-fold (0.40 log units) above; the range from low to high includes it.
By their numbers in this assay, from the lowest: compounds 1, 3 and 4 (each within the scatter of the next); then compound 2.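

Placing 3-methoxyphenyl on the aromatic nitrogen gives a 2.0-fold higher number from compound 1 to compound 4 (0.30 log units; within the scatter) and no change at the digits printed from compound 3 to compound 4 (within the scatter), so in this assay this group cannot be told apart from 2-fluorophenyl or 2-methylphenyl. The new information lies in the step with methyl in place of hydrogen on the oxygen, which gives a 5.1-fold lower number from compound 2 to compound 4 (0.71 log units; beyond the scatter), so among these compounds the weaker result of compound 2 goes with the hydroxyl hydrogen and not with the ring oxygen alone. Nothing measured here gives a reason for this step.

The compounds shown leave open how much of the phenyl group can change before the number rises again, since only small groups on that ring appear here. A longer chain such as ethoxy in place of methoxy, or an amine or a carboxylic acid on the phenyl ring, would test this.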